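The source may report more compounds than this note shows. Statements on the series, on what has been measured and on what is new or still open speak of the compounds shown alone.

Of the compounds shown here, three sharing one core have been measured for cytotoxicity. Compound 1 `O=C(Nc1c(O)cccc1-c1nc2c(C(=O)O)cccc2o1)c1ccccc1O` gives 85100 nM in an ADME assay on L6 cells (Rattus norvegicus) for cytotoxicity; a lower number here means a stronger inhibitor, a higher number a weaker inhibitor. Compound 2 `O=C(Nc1c(O)cccc1-c1nc2c(C(=O)O)cccc2o1)c1ccc(F)c(F)c1F` gives 210000 nM in this assay, and compound 3 `O=C(Nc1c(O)cccc1-c1nc2c(C(=O)O)cccc2o1)c1cc(-c2ccccc2)nc2ccccc12` gives 108000 nM in this assay. Among these three numbers compound 2 stands highest: the number of compound 3 is its nearest and lies within the usual scatter of its own, while the step of a 2.5-fold higher number from compound 1 to compound 2 (0.39 log units; beyond the scatter) lies beyond the scatter.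

Compound 4 `O=C(Nc1c(O)cccc1-c1nc2c(C(=O)O)cccc2o1)c1ncccc1O` has not yet been measured in this assay. It differs from compound 2 in one place: 3-hydroxypyridin-2-yl in place of 2,3,4-trifluorophenyl on a carbonyl carbon. Among the measured compounds shown here, the only measured step that bears on this change is a 2.5-fold higher number from compound 1 to compound 2 (0.39 log units; beyond the scatter), where a 2-hydroxyphenyl on a carbonyl carbon gave the lower number and the 2,3,4-trifluorophenyl the higher one. The group that enters in compound 4 carries a hydroxy group in its name, as the group in compound 1 does, and the fluorine atoms leave. Compound 4 is therefore expected to move back toward the number of compound 1, by an estimated step of a 2.1-fold lower number from compound 2 to compound 4 (0.32 log units; beyond the scatter). The estimate for compound 4 in this assay is 100000 nM, with an expected range from 40000 nM to 250000 nM.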

Compound 4, half-maximal inhibitory concentration: 14200 nM
Compound 4: middle estimate off by 7.0-fold (0.85 log units), on the high side; the measured number lies below the stated range.
By their numbers in this assay, from the lowest: compound 4; then compounds 1, 3 and 2 (each within the scatter of the next, the first and the last beyond it).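

In this assay, among the compounds shown here, the place on a carbonyl carbon whose other neighbours are an amide-type nitrogen proves far more responsive than the earlier compounds showed: a 15-fold lower number from compound 2 to compound 4 (1.17 log units; beyond the scatter) is a much larger move than a 2.5-fold higher number from compound 1 to compound 2 (0.39 log units; beyond the scatter), the only step known before. The hydroxy group alone does not set the number, since a 6.0-fold lower number from compound 1 to compound 4 (0.78 log units; beyond the scatter) separates two groups that both carry one, and in this pair the six-membered aromatic ring with 1 hetero atom gives the lower number and the ring of carbon only the higher one. For the compounds shown here, nothing presented here explains why the 3-hydroxypyridin-2-yl group moves the number so far.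

The compounds shown leave open whether the ring nitrogen can produce this drop without the hydroxy group, as an unsubstituted pyridin-2-yl group would test, or whether the two must occur together. They also leave open how the number responds when an amine or a carboxylic acid takes the place of the hydroxy group on the same pyridine ring.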